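Quinoline thiosemicarbazones: aryl change at the amide nitrogen

A few compounds are considered here, and "the series" means these few. Any claim that something is new, unique, unknown or untested is made for them only; others in the source may bear on it.

Values obtained in a functional assay on HL-60 cells (Homo sapiens) for antiproliferative activity, read by sulforhodamine B assay, with a stated time of 72 h (on this read-out lower numbers stand for stronger inhibition and higher numbers for weaker inhibition), for the measured compounds:

compound 1 `Fc1cccc(NC(=S)N/N=C/c2ccc3ccccc3n2)c1` gives 43800 nM
compound 2 `NC(=S)N/N=C/c1cc2cccnc2s1` gives only a limit of the assay, > 100000 nM
compound 3 `NC(=S)N/N=C/c1cnc2ccccc2n1` gives only a limit of the assay, > 100000 nM

Among the compounds with values here, compound 1 is the only member of the set with a number in this assay; the remaining two values are limits, and the limit of > 100000 nM in this assay, at which 2 of the 3 values shown sit, is the sole piece of evidence on the spread of the series. Within the data shown here, no two measured compounds differ in a single place, so no measured step is available to anchor the change examined here.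

Compound 4 `COc1ccccc1NC(=S)N/N=C/c1ccc2ccccc2n1` is the unmeasured analogue. It derives from compound 1 by 2-methoxyphenyl in place of 3-fluorophenyl on an amide-type nitrogen. Both leaving and entering groups are a single six-membered aromatic ring of carbon only attached at the same amide-type nitrogen, so the change is confined to the substituent on that ring and its position. With no measured step of this kind in the set, the expected movement from compound 1 to compound 4 in this assay is a 1.0-fold higher number from compound 1 to compound 4 (0.01 log units; within the scatter), not beyond the usual scatter in either direction. Compound 4 is therefore estimated at 45000 nM, within a range from 15000 nM to 100000 nM, with a real chance that the assay returns only a limit.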

Compound 4, half-maximal inhibitory concentration: 91700 nM
Compound 4: the middle estimate sits 2.0-fold (0.31 log units) below what was measured; low and high end bracket the measured number.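

Within the data shown here, the aryl group on the amide-type nitrogen is not a silent position in this assay: 2-methoxyphenyl in place of 3-fluorophenyl gives a 2.1-fold higher number from compound 1 to compound 4 (0.32 log units; beyond the scatter), a modest change and the first measured step. Because the substituent and its place on the ring change together, this single step cannot separate the effect of gaining the methoxy group, losing the fluorine or moving the substituent. Little room remains upward before readings in this series stop at a limit of the assay, which is not a number: the limit of > 100000 nM in this assay, at which 2 of the 4 values shown sit.

Open, going by these compounds, is whether any replacement at this nitrogen can lower the number rather than raise it, since the two aryl groups compared here both leave the series at the weak end of the read-out. It also remains to be seen how an amine or a carboxylic acid on the same six-membered ring, or a longer chain in place of that ring, would behave, and whether either would shift the number by more than this modest step.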